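Replacing chloro with methoxycarbonyl in compound 4

A few compounds are considered here, and "the series" means these few. Any claim that something is new, unique, unknown or untested is made for them only; others in the source may bear on it.

Going by the values given here, in a functional assay on A549 cells (Homo sapiens) for cytotoxicity, read by MTT assay, with a stated time of 68 h (a higher number here means a weaker inhibitor, a lower number a stronger inhibitor), compound 3 `O=C(Nc1cccc(-c2ccc(Cl)cc2)c1)C(Cl)Cl` gives 36200 nM, the higher of the two exact numbers measured so far. Compound 2 `O=C(Nc1cccc(-c2ccc(F)cc2)c1)C(Cl)Cl` gives 7840 nM. Compound 1 `O=C(Nc1cccc(-c2ccc(-c3ccccc3)cc2)c1)C(Cl)Cl` reads > 50000 nM, which is a limit of the assay and not a number. Compound 4 `COC(=O)c1ccc(-c2cccc(NC(=O)C(Cl)Cl)c2)cc1` has methoxycarbonyl in place of chloro on an aromatic carbon, para to a large group: methoxycarbonyl in place of chloro on an aromatic carbon. Three measured steps change this same place. They show a 4.6-fold higher number from compound 2 to compound 3 (0.66 log units; beyond the scatter), an at least 6.3-fold lower number from compound 1 to compound 2 (0.80 log units; beyond the scatter) and an at least 1.3-fold lower number from compound 1 to compound 3 (0.14 log units; that floor lies within the scatter). These steps do not settle a direction for a new group, so no step beyond the scatter is expected in this assay. The expected change is a 1.6-fold lower number from compound 3 to compound 4 (0.22 log units; within the scatter). For compound 4 the estimated value is 22000 nM, with an expected range of 8000 nM to 50000 nM.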

Compound 4, half-maximal inhibitory concentration: > 50000 nM
Compound 4: only a limit was reported (the forecaster's own chance of this, stated with the estimate: 20%); at least 2.2-fold (0.35 log units) between middle value and limit.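

Compound 4 ends at a limit of this assay, not at a number, and so does compound 1: the limit of > 50000 nM in this assay, at which 2 of the 4 values shown sit. Against fluoro the change is clear, with an at least 6.3-fold higher number from compound 2 to compound 4 (0.80 log units; beyond the scatter), while against chloro it is not, with an at least 1.3-fold higher number from compound 3 to compound 4 (0.14 log units; that floor lies within the scatter). Compound 2 now stands apart from all three other compounds, with each step beyond the scatter.

The step between compound 1 and compound 4 cannot be read, as both values are limits. From the compounds shown here alone, whether an amine or a hydroxyl group at this place would give a number near that of compound 2 stays open.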